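A Dichlorophenyl Swap on a Weakly Active Compound

This account rests on a few compounds, and the source may have more. Where it says the series, first, only, none or still open, it means among the compounds named here.

In a functional assay on HL-60 cells (Homo sapiens) for antiproliferative activity, read by MTT assay, with a stated time of 24 h (on this read-out lower numbers stand for stronger inhibition and higher numbers for weaker inhibition), compound 1 `CNC(=O)c1ccccc1Oc1nc(Nc2ccc(C(F)(F)F)cc2)ncc1Br` gives > 50000 nM, which is a limit of the assay and not a number. Compound 2 `CNC(=O)c1ccccc1Oc1nc(Nc2cccc(Br)c2)ncc1Br` gives 38700 nM. Compound 3 `Cc1cccc(Nc2ncc(Br)c(Oc3cccc(F)c3)n2)c1` gives 15500 nM, the lower of the two actual numbers and a gap beyond the usual scatter. Compound 4 `Cc1cccc(Nc2ncc(Br)c(Oc3cc(Cl)cc(Cl)c3)n2)c1` carries 3,5-dichlorophenyl in place of 3-fluorophenyl on an oxygen on an aromatic ring. Among the compounds with values here, no two measured compounds differ in one place alone, so any forecast here is rough. In this assay, the expected change is a modest one toward stronger inhibition, a 2.2-fold lower number from compound 3 to compound 4 (0.35 log units; beyond the scatter). The estimate for compound 4 is 7000 nM, with an expected range of 2000 nM to 25000 nM.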

Compound 4, half-maximal inhibitory concentration: > 50000 nM
Compound 4 was reported as a limit (the forecaster's own chance of this, stated with the estimate: 8%); at least 7.1-fold (0.85 log units) between middle value and limit.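

In this assay, the swap on an oxygen on an aromatic ring gives an at least 3.2-fold higher number from compound 3 to compound 4 (0.50 log units; beyond the scatter), so 3,5-dichlorophenyl weakens inhibition here relative to 3-fluorophenyl. This is the first one-place comparison among the compounds shown, and it shows that activity in this series responds to the group at this position. The entry for compound 4 is a limit of the assay and not a number, so the full size of the step cannot be read: the limit of > 50000 nM in this assay, at which 2 of the 4 values shown sit.

Still open, going by these compounds, is whether the change of halogen or the second chlorine matters more. A 3-chlorophenyl group at this position would separate the two, and an unsubstituted phenyl would show what the halogens contribute at all.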